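Methoxy for hydroxy on the aryl triazole

A few compounds are considered here, and "the series" means these few. Any claim that something is new, unique, unknown or untested is made for them only; others in the source may bear on it.

Three compounds with a shared core have been run in a functional assay on OVCAR-3 cells (Homo sapiens) for inhibition, read by MTT assay, with a stated time of 24 h; a lower number here means a stronger inhibitor, a higher number a weaker inhibitor. Compound 1 `CC1(C)[C@H]2CC[C@]1(C)N(Cc1cn(-c3cccc(Cl)c3)nn1)C(=O)C2` gives 50 nM in this assay. Compound 2 `CC1(C)[C@H]2CC[C@]1(C)N(Cc1cn(-c3ccc(Cl)cc3)nn1)C(=O)C2` gives 160 nM in this assay, and the step of a 3.2-fold higher number from compound 1 to compound 2 (0.51 log units; beyond the scatter) is the only one beyond the scatter. Compound 3 `CC1(C)[C@H]2CC[C@]1(C)N(Cc1cn(-c3ccccc3O)nn1)C(=O)C2` gives 90 nM in this assay; it stands second highest of the three numbers, yet the steps of a 1.8-fold higher number from compound 1 to compound 3 (0.26 log units; within the scatter) and a 1.8-fold lower number from compound 2 to compound 3 (0.25 log units; within the scatter) both fall within the scatter, so no order can be read among compounds 1, 2 and 3 beyond the step between compounds 1 and 2.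

Compound 4 `COc1ccccc1-n1cc(CN2C(=O)C[C@@H]3CC[C@@]2(C)C3(C)C)nn1` is not yet measured. Its change from compound 3 is methyl in place of hydrogen on an oxygen on an aromatic ring. For the measured compounds named here, none of the measured steps bears on this change: every step so far exchanges one aromatic substituent for another, and no compound carrying a methyl on that oxygen has been run. Going by the values given here, with no guiding step, the expected step of a 1.2-fold higher number from compound 3 to compound 4 (0.09 log units; within the scatter) is one of no change beyond the scatter. Compound 4 is therefore estimated at 110 nM in this assay, within a range of 40 nM to 300 nM.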

Compound 4, half-maximal inhibitory concentration: 140 nM
Beside the measured number, compound 4's estimate is 1.3-fold (0.10 log units) below it; measured number inside the range.
By their numbers in this assay, from the lowest: compounds 1, 3, 4 and 2 (each within the scatter of the next, the first and the last beyond it).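

Methyl in place of hydrogen on this oxygen leaves the number in this assay little moved, with a 1.6-fold higher number from compound 3 to compound 4 (0.19 log units; within the scatter) as the step, so this single pair gives no sign that the hydroxy hydrogen matters in the 2-hydroxyphenyl series. The 2-methoxyphenyl group also cannot be told apart from 4-chlorophenyl, given a 1.1-fold lower number from compound 2 to compound 4 (0.06 log units; within the scatter) as the step, yet it does separate from 3-chlorophenyl, with a 2.8-fold higher number from compound 1 to compound 4 (0.45 log units; beyond the scatter) beyond the scatter, which 2-hydroxyphenyl did not do. No measurement on the compounds speaks to the reason for these steps.

As far as these compounds go, whether an ethoxy group, a longer chain on the same oxygen or an amine in its place would stay within the scatter of compound 3 remains open. So does whether methoxy behaves the same way elsewhere on the phenyl ring.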